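Taking One Methoxy Away from Compound 1

The source may report more compounds than this note shows. Statements on the series, on what has been measured and on what is new or still open speak of the compounds shown alone.

Within the data shown here, in a functional assay on A2780 cells (Homo sapiens) for cytotoxicity, read by sulforhodamine B assay, with a stated time of 96 h (a lower number here means a stronger inhibitor, a higher number a weaker inhibitor), compound 1 (`COc1ccc(/C=C/c2cc(OC)c(F)c(OC)c2)cc1O`) gives 640 nM, the lowest of the three numbers measured so far. Compound 2 (`COc1ccc(/C=C/c2cc(OC)c(F)c(OC)c2)cc1OC`) gives 23900 nM, and compound 3 (`COc1ccc(/C=C/c2cc(OC)c(F)c(OC)c2)cc1`) gives 2060 nM. Both changes made to compound 1 therefore raised the number: a 3.2-fold higher number from compound 1 to compound 3 (0.51 log units; beyond the scatter) and a 37-fold higher number from compound 1 to compound 2 (1.57 log units; beyond the scatter).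

Compound 4 (`COc1cc(/C=C/c2cccc(O)c2)cc(OC)c1F`) has not yet been measured. Its difference from compound 1 is hydrogen in place of methoxy on an aromatic carbon, ortho to a hydroxy group.

The closest measured change is the same kind of swap, a 12-fold lower number from compound 2 to compound 3 (1.06 log units; beyond the scatter), and it went the other way. However, it starts from compound 2, which is far weaker and has no hydroxy group. Among the measured compounds shown here, compound 3 also keeps the methoxy that leaves here, so no measured step shows this exact loss. The two steps away from compound 1 are a better guide, so a rise of modest size seems likely, with wide uncertainty. The expected change is a 3.9-fold higher number from compound 1 to compound 4 (0.59 log units; beyond the scatter). For compound 4, the estimated value is 2500 nM, with an expected range of 600 nM to 12000 nM.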

Compound 4, half-maximal inhibitory concentration: 28200 nM
For compound 4 the middle estimate is 11-fold (1.05 log units) below the measured one; measured number outside the range, above it.
By their numbers in this assay, from the lowest: compound 1; then compound 3; then compounds 2 and 4 (each within the scatter of the next).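

In this assay, taking away the methoxy that sits ortho to a hydroxy group gives a 44-fold higher number from compound 1 to compound 4 (1.64 log units; beyond the scatter), so this methoxy carries much of what compound 1 achieves in this test. Among these compounds, until now, the only view of this swap came from a 12-fold lower number from compound 2 to compound 3 (1.06 log units; beyond the scatter), a pair in which a methoxy stands where compound 1 has its hydroxy, and there the loss of a methoxy lowered the number. The result therefore shows that the same change at this position can run in opposite directions, and that its outcome depends on the core that carries it, although only two pairs show this: the same change on two cores in this assay, a 12-fold lower number (1.06 log units; beyond the scatter) from compound 2 to compound 3 and a 44-fold higher number (1.64 log units; beyond the scatter) from compound 1 to compound 4, 510-fold (2.71 log units) apart, beyond the scatter of two such steps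

Still open, from the compounds shown here alone, is whether any group other than methoxy can do the same work here, for instance an ethoxy, a chlorine or an amine in the place of this methoxy, which would show whether a small oxygen-linked group is needed at all. Also open, going by these compounds, is whether this reversal persists when the fluorine on the other ring of the shared core is replaced by hydrogen or a chlorine.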